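Working notes on a small cytotoxicity series

The source may hold more compounds than are shown below. What is called first, only, known or untested is meant among the compounds shown, and "the series" means these compounds.

Of the compounds shown here, three have been measured in a functional assay on HL-60 cells (Homo sapiens) for cytotoxicity, read by MTT assay, with a stated time of 72 h; on this read-out higher numbers stand for weaker inhibition and lower numbers for stronger inhibition. Compound 1 `COc1ccc(S(=O)(=O)c2nc3ccccc3nc2Nc2cc(OC)cc(OC)c2)cc1` gives 1710 nM in this assay. Compound 2 `COc1ccc(S(=O)(=O)c2nc3ccccc3nc2Nc2ccc(N)cc2)cc1` gives 710 nM in this assay, and compound 3 `COc1cc(Nc2nc3ccccc3nc2S(=O)(=O)c2ccc(Br)cc2)cc(OC)c1` gives 2540 nM in this assay. Compound 3 carries the highest number of the three, but its gap to compound 1 lies within the scatter, so no order between those two is claimed; its gap to compound 2 lies beyond the scatter.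

Two single changes connect the measured compounds. From compound 1 to compound 2 the change is 4-aminophenyl in place of 3,5-dimethoxyphenyl on a nitrogen on an aromatic ring, and it made the step of a 2.4-fold lower number from compound 1 to compound 2 (0.38 log units; beyond the scatter). From compound 1 to compound 3 the change is bromo in place of methoxy on an aromatic carbon, with the step of a 1.5-fold higher number from compound 1 to compound 3 (0.17 log units; within the scatter), so the two cores differ in that one point only.

Compound 4 `Nc1ccc(Nc2nc3ccccc3nc2S(=O)(=O)c2ccc(Br)cc2)cc1` has not yet been measured in this assay. It differs from compound 3 by 4-aminophenyl in place of 3,5-dimethoxyphenyl on a nitrogen on an aromatic ring, which is the same change as that from compound 1 to compound 2; the place is described in the same words in both cases. Going by the values given here, for compound 4 a step of about a 2.3-fold lower number from compound 3 to compound 4 (0.36 log units; beyond the scatter) in this assay is expected, resting on the single earlier instance of this change, a 2.4-fold lower number from compound 1 to compound 2 (0.38 log units; beyond the scatter). Since that instance stands alone, the expectation is held loosely. Compound 4 is thus estimated at 1100 nM in this assay, with a range from 500 nM to 2500 nM.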

Compound 4, half-maximal inhibitory concentration: 730 nM
For compound 4 the middle estimate is 1.5-fold (0.18 log units) above the measured one; measured number inside the range.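

In this assay the exchange of 3,5-dimethoxyphenyl for 4-aminophenyl gives a 3.5-fold lower number from compound 3 to compound 4 (0.54 log units; beyond the scatter), and this agrees with its earlier instance: the same change on two cores in this assay, a 2.4-fold lower number (0.38 log units; beyond the scatter) from compound 1 to compound 2 and a 3.5-fold lower number (0.54 log units; beyond the scatter) from compound 3 to compound 4, 1.4-fold (0.16 log units) apart, within the scatter of two such steps The exchange of methoxy for bromo, read on the cores carrying 4-aminophenyl, gives a 1.0-fold higher number from compound 2 to compound 4 (0.01 log units; within the scatter), so no order is claimed within that pair, and this step also agrees with its earlier instance: the same change on two cores in this assay, a 1.5-fold higher number (0.17 log units; within the scatter) from compound 1 to compound 3 and a 1.0-fold higher number (0.01 log units; within the scatter) from compound 2 to compound 4, 1.4-fold (0.16 log units) apart, within the scatter of two such steps Each change therefore carried over between the two cores available to it, but those cores differ in a single point and the two comparisons draw on the same four compounds, so this is one closed set rather than independent confirmation, and it neither extends to a core altered elsewhere nor explains the steps.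

The compounds shown leave open whether the step on the nitrogen persists with other groups there, such as a phenyl ring bearing a carboxylic acid or a nitrile, or a plain alkyl chain in place of the aromatic ring. They also leave open whether other groups on the aromatic carbon, such as chloro or trifluoromethyl, would stay as close to bromo and methoxy on both cores.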